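Swapping 4-Bromophenyl for 2-Methylphenyl: an Antiproliferative Estimate

A few compounds are considered here, and "the series" means these few. Any claim that something is new, unique, unknown or untested is made for them only; others in the source may bear on it.

Compound 1 `O=c1c2ccccc2[se]n1-c1nnc(-c2ccc(Br)cc2)s1`: 68200 nM
Compound 2 `COc1cc(-c2nnc(-n3[se]c4ccccc4c3=O)s2)cc(OC)c1OC`: 7150 nM

Both numbers come from a functional assay on SSMC-7721 cells (Homo sapiens) for antiproliferative activity, read by CCK-8 assay, with a stated time of 48 h; on this read-out lower numbers stand for stronger inhibition and higher numbers for weaker inhibition. Compound 1 stands highest of the two; compound 2 sits at a lower number, and that gap lies beyond the usual scatter. Compound 3 `Cc1ccccc1-c1nnc(-n2[se]c3ccccc3c2=O)s1` follows from compound 1 by one change: 2-methylphenyl in place of 4-bromophenyl on an aromatic carbon. Within the data shown here, no measured pair shows what this change does, so the expected step of a 1.7-fold lower number from compound 1 to compound 3 (0.23 log units; within the scatter) is set small, probably within the scatter, with wide uncertainty in either direction. Compound 3 is estimated at 40000 nM, within a range from 12000 nM to 130000 nM.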

Compound 3, half-maximal inhibitory concentration: 19400 nM
The estimate for compound 3 lay 2.1-fold (0.31 log units) above the measured number; measured number inside the range.
By their numbers in this assay, from the lowest: compound 2; then compound 3; then compound 1.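

In this assay, 2-methylphenyl in place of 4-bromophenyl on this aromatic carbon gives a 3.5-fold lower number from compound 1 to compound 3 (0.55 log units; beyond the scatter) and so shows that this position responds to the aryl group it carries. The change holds the count of heavy atoms and the carbon-only aromatic ring steady, yet the number still moves. No measurement shown here explains the shift.

From the compounds shown here alone, it remains open whether the methyl, the loss of bromine or the place of the group on the phenyl ring matters most. Plain phenyl, 4-methylphenyl and 2-bromophenyl would separate these, and an aminophenyl group would test a different kind of substituent.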